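A few compounds are considered here, and "the series" means these few. Any claim that something is new, unique, unknown or untested is made for them only; others in the source may bear on it.

Values so far in a functional assay on K562 cells (Homo sapiens) for antiproliferative activity, read by MTT assay; a higher number here means a weaker inhibitor, a lower number a stronger inhibitor:
- compound 1 `O=C(CCCCCNC(=S)NN=C(c1ccccc1)c1ccccc1)NO` gives 3810 nM
- compound 2 `C/C(=N\NC(=S)NCCCCCC(=O)NO)c1ccc(Br)cc1` gives 960 nM
- compound 3 `C/C(=N\NC(=S)NCCCCCC(=O)NO)c1cccc(Br)c1` gives 1260 nM

Compound 1 stands highest of the three, and its gaps to compound 3 and compound 2 both lie beyond the scatter. Next is compound 4 `O=C(CCCCCNC(=S)N/N=C(\c1ccccc1)c1ccc([N+](=O)[O-])cc1)NO` which differs from compound 1 by nitro in place of hydrogen on an aromatic carbon with the nitro para to a large group.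

Within the data shown here, the only measured step (a 1.3-fold higher number from compound 2 to compound 3 (0.12 log units; within the scatter)) exchanges one bromophenyl for another and adds no group, so it bears only loosely on this change. Compound 2 and compound 3 differ from compound 1 in more than one place, so their lower numbers cannot be assigned to the bromine alone. The data therefore give only a weak lean towards a lower number. In this assay a step of a 1.5-fold lower number from compound 1 to compound 4 (0.18 log units; within the scatter) is expected, which means no expected change beyond the scatter. For compound 4 the estimated value is 2500 nM with an expected range from 1000 nM to 6000 nM in this read-out.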

Compound 4, half-maximal inhibitory concentration: 2890 nM
For compound 4 the middle estimate is 1.2-fold (0.06 log units) below the measured one, within the range that was stated.
By their numbers in this assay, from the lowest: compounds 2 and 3 (each within the scatter of the next); then compounds 4 and 1 (each within the scatter of the next).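

In this assay, nitro in place of hydrogen on an aromatic carbon of a six-membered aromatic ring of carbon only, para to a large group, comes with a 1.3-fold lower number from compound 1 to compound 4 (0.12 log units; within the scatter). Unlike the exchange of one bromophenyl for another in the earlier step, this step adds a group to the core of compound 1, and the added nitro leaves the number within the scatter at this position. No measurement at hand speaks to the reason for this result.

On these data alone, whether an amine or a carboxylic acid at this same position would also stay within the scatter remains open. Also open, as far as these compounds go, is whether a bromine here, or a longer chain on the hydroxamic acid side of the core of compound 1, would move the number beyond it.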